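Biaryl sulfonamide series: aryl variation at the distal ring

The compounds below may be only part of what the source reports. "The series", "measured", "known", "first", "only" and "open" are said of these compounds alone.

Measured so far, in an assay on isolated protein for displacement of a labelled ligand from 5-hydroxytryptamine receptor 6 (Homo sapiens), read by radioligand binding; a lower number here means a stronger inhibitor, a higher number a weaker inhibitor:
- compound 1 `CC(C)c1cc2c(cc1NS(=O)(=O)c1ccc(-c3ccc(Cl)cc3)cc1)CCN(C)CC2`: 12.6 nM
- compound 2 `CN1CCc2ccc(NS(=O)(=O)c3ccc(-c4ccc(F)c(Cl)c4)cc3)cc2CC1`: 7.94 nM
- compound 3 `Cc1noc(C)c1-c1ccc(S(=O)(=O)Nc2ccc3c(c2)CCN(C)CC3)cc1`: 10 nM

All three share the sulfonamide on the bicyclic amine core and differ in the aryl group attached to the sulfonyl-bearing ring. Compound 3 stands second highest of the three numbers; its nearest neighbour is compound 2, and its furthest is compound 1, both at gaps this assay cannot separate from repeat scatter. Going by the values given here, the only single-point step recorded within this set, a 1.3-fold higher number from compound 2 to compound 3 (0.10 log units; within the scatter), replaced one aryl group by another and produced no movement beyond the scatter.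

The next compound, compound 4 `Cc1ccc(-c2ccc(S(=O)(=O)Nc3ccc4c(c3)CCN(C)CC4)cc2)s1`, is compound 3 with 5-methylthiophen-2-yl in place of 3,5-dimethyl-1,2-oxazol-4-yl on an aromatic carbon. Among the compounds with values here, the one comparable step, from compound 2 to compound 3, swapped the distal aromatic group and left this assay essentially unchanged, and compound 1 with its own distinct aryl group lies in the same band. On that basis the expected step of a 1.1-fold lower number from compound 3 to compound 4 (0.05 log units; within the scatter) is no change beyond the scatter, in either direction.

Compound 4 is therefore estimated at 9 nM in this assay, with a plausible range from 3.5 nM to 25 nM.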

Compound 4, inhibition constant: 6.31 nM
For compound 4 the middle estimate is 1.4-fold (0.15 log units) above the measured one; the range from low to high includes it.
By their numbers in this assay, from the lowest: compounds 4, 2, 3 and 1 (each within the scatter of the next).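

In this assay, the aromatic carbon para to a large group now holds a third distal group, 5-methylthiophen-2-yl. Its exchange for 3,5-dimethyl-1,2-oxazol-4-yl gives a 1.6-fold lower number from compound 3 to compound 4 (0.20 log units; within the scatter), and its exchange for 3-chloro-4-fluorophenyl gives a 1.3-fold lower number from compound 2 to compound 4 (0.10 log units; within the scatter), so compound 2, compound 3 and compound 4 cannot be told apart here, even though the entering group has one five-membered aromatic ring with 1 hetero atom, sulfur, and 1 hydrogen-bond acceptor, where the 3,5-dimethyl-1,2-oxazol-4-yl group has 2 hetero atoms and 2 hydrogen-bond acceptors. The earlier step had shown this only for one pair of groups, whereas this position now reads alike across a six-membered carbon ring and two different five-membered aromatic rings, and no measurement available here accounts for that sameness.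

Every distal group shown is aromatic, so the response to an amine such as piperidine, a carboxylic acid or an open alkyl chain at this carbon remains open. The isopropyl group on the core of compound 1 comes with a different distal group as well, so its own contribution remains unresolved.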